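Mirror-image pair: where lipophilicity is expected to land

A few compounds are considered here, and "the series" means these few. Any claim that something is new, unique, unknown or untested is made for them only; others in the source may bear on it.

Measured so far:
compound 1 `O=S(=O)(Nc1nccs1)c1ccc2c(c1)OCC[C@H]2c1ccc(C(F)(F)F)cc1-c1ccc(F)nc1`: "not determined" (no result reported)
compound 2 `Cn1nccc1-c1cc(C(F)(F)F)ccc1[C@@H]1CCOc2cc(S(=O)(=O)Nc3nccs3)ccc21`: 2.2

Compound 1 has no result in a physicochemical assay for lipophilicity (a lower number here means a more polar compound, a higher number a more lipophilic compound), and so stands nowhere on the numbers shown. Among the measured compounds shown here, the only reading belongs to compound 2, which in this assay gives 2.2. Compound 3 `O=S(=O)(Nc1nccs1)c1ccc2c(c1)OCC[C@@H]2c1ccc(C(F)(F)F)cc1-c1ccc(F)nc1` is the partner of compound 1: the two compounds have the same atoms and bonds and differ only in configuration as drawn: 1 of 1 stereo elements differ; a stereocentre at a saturated ring carbon is drawn S in compound 1 and R in compound 3. For the measured compounds named here, no step between measured compounds covers such a change; for a pair differing only in configuration, no shift beyond the scatter is expected in this assay, in either direction. With compound 2 giving 2.2 as the nearest anchor, compound 3 is estimated at 2.6, range 1.9 to 3.3.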

Compound 3, distribution coefficient: 3.2
The estimate for compound 3 lay 0.60 log units below the measured number; the range from low to high includes it.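

No new step can be read from compound 3, as its mirror-image partner, compound 1, has no number to set against it in this assay. The compounds shown leave open whether configuration alone shifts the reading in this assay.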